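Removing a Methyl From the Side-Chain Ether

The compounds below may be only part of what the source reports. "The series", "measured", "known", "first", "only" and "open" are said of these compounds alone.

The three measured compounds share one core and differ at the saturated chain on the ring and in the halogens on the pendant aryl ring. Compound 1 `Cn1ncc(Cl)c1-c1cc(C(=O)N[C@@H]2CN[C@H](CCO)C[C@H]2c2ccc(F)c(F)c2)oc1Cl` in a functional assay on LNCaP cells (Homo sapiens) for antiproliferative activity (a lower number here means a stronger inhibitor, a higher number a weaker inhibitor), gives 60 nM. Compound 2 `Cn1ncc(Cl)c1-c1cc(C(=O)N[C@@H]2CN[C@H](CCN3CCC(O)CC3)C[C@H]2c2ccc(Cl)c(Cl)c2)oc1Cl` in this assay gives 1140 nM, and compound 3 `COCC[C@@H]1C[C@@H](c2ccc(Cl)c(Cl)c2)[C@H](NC(=O)c2cc(-c3c(Cl)cnn3C)c(Cl)o2)CN1` in this assay gives 250 nM, the second highest of the three numbers. For the measured compounds named here, the one step within this set, a 4.6-fold lower number from compound 2 to compound 3 (0.66 log units; beyond the scatter), runs from a bulky ring-bearing chain end to a small methoxy, a modest gain.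

Compound 4 `Cn1ncc(Cl)c1-c1cc(C(=O)N[C@@H]2CN[C@H](CCO)C[C@H]2c2ccc(Cl)c(Cl)c2)oc1Cl` is the next compound, and it differs from compound 3 by hydrogen in place of methyl on an oxygen on a saturated carbon. The measured step from compound 2 to compound 3 bears on it only loosely, as both steps trim the same chain end. More telling, compound 1 carries the same hydroxyethyl chain and gives the lowest number shown, though its aryl halogens differ from those of compound 4, so no step links them directly.

Taken together, compound 4 is expected to land somewhat below compound 3, an estimated step of a 2.1-fold lower number from compound 3 to compound 4 (0.32 log units; beyond the scatter). Compound 4 is therefore estimated at 120 nM in this assay, within a range of 50 nM to 300 nM.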

Compound 4, half-maximal inhibitory concentration: 160 nM
Compound 4: the middle estimate sits 1.3-fold (0.12 log units) below what was measured; low and high end bracket the measured number.
By their numbers in this assay, from the lowest: compound 1; then compounds 4 and 3 (each within the scatter of the next); then compound 2.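

Exchanging the 2-methoxyethyl chain for 2-hydroxyethyl gives a 1.6-fold lower number from compound 3 to compound 4 (0.19 log units; within the scatter), so in this assay this position shows no readable difference between methyl and hydrogen on the oxygen. For the compounds shown here, the larger step at this chain end is a 7.1-fold lower number from compound 2 to compound 4 (0.85 log units; beyond the scatter), which shows that hydroxy in place of 4-hydroxypiperidin-1-yl counts for much more here than the methyl does, while a 2.7-fold higher number from compound 1 to compound 4 (0.43 log units; beyond the scatter) gives the first direct comparison of the aryl halogens with the 2-hydroxyethyl chain held fixed, 3,4-dichlorophenyl in place of 3,4-difluorophenyl. No measurement shown here accounts for any of these steps.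

From the compounds shown here alone, whether the gap between 3,4-difluorophenyl and 3,4-dichlorophenyl carries over to the 2-methoxyethyl chain remains open. So does what a primary amine, a carboxylic acid or a longer chain ending in hydroxy would give at this position, and whether any of them would separate from the 2-hydroxyethyl and 2-methoxyethyl chains in this assay's numbers.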